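The source may report more compounds than this note shows. Statements on the series, on what has been measured and on what is new or still open speak of the compounds shown alone.

Measured in a functional assay on HeLa cells (Homo sapiens) for inhibition, read by sulforhodamine B assay, with a stated time of 74 h; on this read-out lower numbers stand for stronger inhibition and higher numbers for weaker inhibition:

- Compound 1 `CS(=O)(=O)N1C(=O)COC12C=CC(=O)C=C2`: 7530 nM
- Compound 2 `Cc1ccccc1S(=O)(=O)N1C(=O)COC12C=CC(=O)C=C2`: 3720 nM
- Compound 3 `O=C1C=CC2(C=C1)OCC(=O)N2S(=O)(=O)c1ccc([N+](=O)[O-])cc1`: > 10000 nM

Compound 3 has no exact number, since its > 10000 nM is only a limit of the assay. Compound 4 `O=C1C=CC2(C=C1)OCC(=O)N2S(=O)(=O)c1ccc(OC(F)(F)F)cc1` has not yet been measured. It differs from compound 3 in one place, with trifluoromethoxy in place of nitro on an aromatic carbon.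

Among the measured compounds shown here, no measured step changes this group, so the evidence is indirect. For the measured compounds named here, the only measured step, a 2.0-fold lower number from compound 1 to compound 2 (0.31 log units; beyond the scatter), is a change on the sulfonyl sulfur, and its size is modest. Compound 2, with 3720 nM, shows that a compound with an aromatic ring on the sulfonyl sulfur can give a number in this assay, so a similar result is expected for compound 4. A modest move toward stronger inhibition is therefore expected, estimated as an at least 2.0-fold lower number from compound 3 to compound 4 (0.30 log units; that floor lies within the scatter). The limit on compound 3 makes the size of this step rough. For compound 4 the expected value is 5000 nM, with an estimated range from 1800 nM to 14000 nM.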

Compound 4, half-maximal inhibitory concentration: > 10000 nM
Compound 4: only a limit was reported; the forecaster's own chance of this, stated with the estimate: 20%; at least 2.0-fold (0.30 log units) between middle value and limit.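

Compound 3 and compound 4 each give only a limit rather than a number, so the step between them cannot be read: the limit of > 10000 nM in this assay, at which 2 of the 4 values shown sit.

Going by these compounds, whether trifluoromethoxy and nitro on the aromatic ring differ at all in inhibition stays open.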